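A few compounds are considered here, and "the series" means these few. Any claim that something is new, unique, unknown or untested is made for them only; others in the source may bear on it.

Measured compounds in a functional assay on MDA-MB-231 cells (Homo sapiens) for antiproliferative activity, read by MTT assay, with a stated time of 48 h; a lower number here means a stronger inhibitor, a higher number a weaker inhibitor:
Compound 1 `C/C(=C\CC/C(C)=C/CC[C@@H]1[C@@]2(C)CCC(=O)C(C)(C)[C@H]2CC[C@@]1(C)O)CC/C=C(\C)C(=O)OCc1cn(-c2ccc(C(F)(F)F)cc2)nn1` gives a limit of the assay, > 150000 nM.
Compound 2 `C#CCOC(=O)/C(C)=C/CC/C(C)=C/CC/C(C)=C/CC[C@@H]1[C@@]2(C)CCC(=O)C(C)(C)[C@H]2CC[C@@]1(C)O` gives 114000 nM.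
Compound 3 `C/C(=C\CC/C(C)=C/CC[C@@H]1[C@@]2(C)CCC(=O)C(C)(C)[C@H]2CC[C@@]1(C)O)CC/C=C(\C)C(=O)OCc1cn(-c2ccccc2C(F)(F)F)nn1` gives a limit of the assay, > 150000 nM.

Going by the values given here, compound 3 thus stands at the ceiling of this assay, and (the limit of > 150000 nM in this assay, at which 2 of the 3 values shown sit), so it cannot be set in order against compound 1, and it lies away from the one numbered value, that of compound 2. Among the compounds with values here, the only measured step that changes the group on the aromatic nitrogen is a step that the two limits leave unreadable from compound 1 to compound 3, which the two limits leave without a readable size. Compound 4 `C/C(=C\CC/C(C)=C/CC[C@@H]1[C@@]2(C)CCC(=O)C(C)(C)[C@H]2CC[C@@]1(C)O)CC/C=C(\C)C(=O)OCc1cn(-c2cccc(C(F)(F)F)c2)nn1` differs from compound 3 by 3-(trifluoromethyl)phenyl in place of 2-(trifluoromethyl)phenyl on an aromatic nitrogen. Within the data shown here, with no readable step to draw on, and both compounds on either side of the one measured change of this kind resting at the limit, the expected outcome is that compound 4 also gives no number, or at most one near the top of the measured range. The estimated step is a number no higher from compound 3 to compound 4 (the limit leaves the size open), which is expected to be none beyond the scatter. Compound 4 is therefore estimated at 150000 nM, within 70000 nM to 320000 nM.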

Compound 4, half-maximal inhibitory concentration: > 150000 nM
Compound 4 was reported as a limit; the forecaster's own chance of this, stated with the estimate: 65%; the middle value sits exactly at the limit.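

Compound 4 gives > 150000 nM, which is a limit of the assay and not a number. The steps linking compound 1, compound 3 and compound 4 therefore cannot be read. The compounds shown leave open whether 2-(trifluoromethyl)phenyl, 3-(trifluoromethyl)phenyl and 4-(trifluoromethyl)phenyl differ at all in this assay.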